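The compounds below may be only part of what the source reports. "The series", "measured", "known", "first", "only" and "open" are said of these compounds alone.

Measured compounds:
Compound 1, `CCOC(=O)c1c(-c2cccc(-c3ccccc3)c2)[nH]c2cc(OC)ccc2c1=O`: in an ADME assay on Raji cells (Homo sapiens) for cytotoxicity, read by luminescence, with a stated time of 72 h (a lower number here means that less compound is needed, a higher number that more compound is needed for the effect), compound 1 gives > 21500 nM, which is a limit of the assay and not a number.
Compound 2, `CCCCOc1cccc(-c2[nH]c3cc(OC)ccc3c(=O)c2C(=O)OCC)c1`: in this assay compound 2 gives > 21500 nM, again a limit of the assay and not a number.

For the measured compounds named here, compound 2 therefore stands at the limit, and so does the only other compound measured; the values shown sit at the limit of > 21500 nM in this assay, at which 2 of the 2 values shown sit. Going by the values given here, the one step between measured compounds, a step that the two limits leave unreadable from compound 1 to compound 2, cannot be read in size because both ends are limits.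

The next compound is compound 3, `CCOC(=O)c1c(-c2cccc(Cl)c2)[nH]c2cc(OC)ccc2c1=O`. Its difference from compound 2 is chloro in place of butoxy on an aromatic carbon. Among the compounds with values here, no measured step bears readably on this change: the step that the two limits leave unreadable from compound 1 to compound 2 is unreadable, and it concerns a different group in place of the butoxy. What can be said is that both measured compounds sit at the limit in this assay, so the expectation for compound 3 rests on that alone. It is estimated that compound 3 will again reach only the limit, with an expected value of 25000 nM (range 8000 nM to 80000 nM). The step this estimate implies, a step that the limit leaves unreadable from compound 2 to compound 3, is expected to be nothing beyond the scatter.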

Compound 3, half-maximal effective concentration: > 21500 nM
Compound 3: a limit, no number; the forecaster's own chance of this, stated with the estimate: 70%; the middle value does not contradict the limit.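

In this assay compound 3 gives > 21500 nM, a limit of the assay and not a number. Neither the step from compound 1 to compound 3 nor the step from compound 2 to compound 3 can be read in size. The compounds shown leave open how phenyl, butoxy and chloro compare in this assay, with every value at one limit: the limit of > 21500 nM in this assay, at which 3 of the 3 values shown sit.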